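Benzamide ring substituent: cyano exchanged for nitro

The source may hold more compounds than are shown below. What is called first, only, known or untested is meant among the compounds shown, and "the series" means these compounds.

Compound 3 `N#Cc1ccc(C(=O)Nc2cccc(-c3oc4cc(-c5ccc(F)cc5)ccc4c(=O)c3O)c2)cc1` stands at the top of the measured numbers: in a functional assay on GTL 16 cells for antiproliferative activity against GTL 16 cell line (Homo sapiens), read by CCK-8 assay, with a stated time of 72 h (on this read-out higher numbers stand for weaker inhibition and lower numbers for stronger inhibition), compound 3 gives 31800 nM. Compound 1 `Cc1ccc(C(=O)Nc2cccc(-c3oc4cc(-c5ccc(F)cc5)ccc4c(=O)c3O)c2)cc1` gives 12900 nM in this assay, and compound 2 `O=C(Nc1cccc(-c2oc3cc(-c4ccc(F)cc4)ccc3c(=O)c2O)c1)c1cc(F)cc(F)c1` gives 7410 nM. The step of a 2.5-fold higher number from compound 1 to compound 3 (0.39 log units; beyond the scatter) and the step of a 4.3-fold higher number from compound 2 to compound 3 (0.63 log units; beyond the scatter) both lie beyond the scatter, whereas a 1.7-fold lower number from compound 1 to compound 2 (0.24 log units; within the scatter) stays within it.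

Compound 4 `O=C(Nc1cccc(-c2oc3cc(-c4ccc(F)cc4)ccc3c(=O)c2O)c1)c1ccc([N+](=O)[O-])cc1` differs from compound 3 in one place: nitro in place of cyano on an aromatic carbon. Going by the values given here, only one measured step touches this very position, the exchange of methyl for cyano, a 2.5-fold higher number from compound 1 to compound 3 (0.39 log units; beyond the scatter), which shows that a change of the group on that aromatic carbon can move the number by a modest amount. The other step, a 4.3-fold higher number from compound 2 to compound 3 (0.63 log units; beyond the scatter), replaces the whole 3,5-difluorophenyl by 4-cyanophenyl and bears on the present exchange only indirectly. Among the compounds with values here, no step from cyano to nitro has been measured, so there is no direct anchor. The expectation is therefore a step of no more than the scatter, a 1.1-fold lower number from compound 3 to compound 4 (0.06 log units; within the scatter), with no clear direction. Compound 4 is estimated at 28000 nM in this assay, within a range of 10000 nM to 80000 nM.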

Compound 4, half-maximal inhibitory concentration: 18200 nM
For compound 4 the middle estimate is 1.5-fold (0.19 log units) above the measured one, and the stated range covers the measured number.
By their numbers in this assay, from the lowest: compounds 2, 1, 4 and 3 (each within the scatter of the next, the first and the last beyond it).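

In this assay, the exchange of cyano for nitro on this aromatic carbon gives a 1.7-fold lower number from compound 3 to compound 4 (0.24 log units; within the scatter) and so does not separate the two groups, and nitro is not separated from methyl at the same place either, at a 1.4-fold higher number from compound 1 to compound 4 (0.15 log units; within the scatter) in the comparison of those two groups. Going by these compounds alone, the step of a 2.5-fold higher number from compound 1 to compound 3 (0.39 log units; beyond the scatter) therefore remains the only exchange on this carbon that lies beyond the scatter, and nitro, within the scatter of both cyano and methyl, does not turn the three groups into a clear order. Compound 2 keeps its distance from the 4-nitrophenyl amide as it does from the 4-cyanophenyl amide, with a 2.5-fold higher number from compound 2 to compound 4 (0.39 log units; beyond the scatter) as a modest step beyond the scatter, although that exchange alters the whole aryl group and not one substituent.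

Still open, going by these compounds, is whether an amine, a carboxylic acid or a longer alkyl chain on this aromatic carbon would move the number further than these groups do, in either direction.
No data at hand give a reason for any of these steps.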